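The source may report more compounds than this note shows. Statements on the series, on what has been measured and on what is new or still open speak of the compounds shown alone.

Compound 2 `C[C@@H](NC(=O)C1(NC(=O)c2cncc(Cl)c2)CC1)c1ccc(-n2nc(Cl)c3ccccc32)cc1F` carries a 5-chloropyridin-3-yl group on a carbonyl carbon of its amide chain. Among the compounds with values here, in an in vivo ADME assay on the whole organism (strain Mongrel) for metabolic stability, with Canis familiaris (Canis lupus familiaris) as the target (on this read-out lower numbers stand for a shorter-lived compound and higher numbers for a longer-lived compound), compound 2 gives 6 h, the lower of the two numbers measured so far. Its neighbour is compound 1 `COc1ncc(C(=O)NC2(C(=O)N[C@H](C)c3ccc(-n4nc(Cl)c5ccccc54)cc3F)CC2)s1`, which differs only in having a 2-methoxy-1,3-thiazol-5-yl group at that carbonyl carbon; in this assay compound 1 gives 8.3 h. The step of a 1.4-fold lower number from compound 1 to compound 2 (0.14 log units; within the scatter) shows that swapping one of these aromatic rings for the other left the half-life essentially unchanged.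

Compound 3 `C[C@@H](NC(=O)C1(NC(=O)c2cncs2)CC1)c1ccc(-n2nc(Cl)c3ccccc32)cc1F` has not been measured yet. It differs from compound 2 by 1,3-thiazol-5-yl in place of 5-chloropyridin-3-yl on a carbonyl carbon. Within the data shown here, the only step that bears on this change is the one from compound 1 to compound 2, where a 1.4-fold lower number from compound 1 to compound 2 (0.14 log units; within the scatter) stayed within the scatter. A similar exchange of a small aromatic ring on the same carbonyl carbon is therefore expected to shift the half-life little, if at all, so the step from compound 2 to compound 3 is estimated as no change at the digits printed from compound 2 to compound 3 (within the scatter). For compound 3 the half-life in this assay is expected to be about 6 h, with a likely range from 3 h to 12 h.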

Compound 3, half-life: 4.3 h
Compound 3: middle estimate off by 1.4-fold (0.14 log units), on the high side; measured number inside the range.
By their numbers in this assay, from the lowest: compounds 3, 2 and 1 (each within the scatter of the next).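

In this assay, the step of a 1.4-fold lower number from compound 2 to compound 3 (0.14 log units; within the scatter) exchanges a six-membered aromatic ring bearing chlorine for a smaller five-membered one with two hetero atoms, and ring size and the chlorine together leave the reading within the scatter. Within the data shown here, the other step, a 1.9-fold lower number from compound 1 to compound 3 (0.29 log units; within the scatter), is cleaner still, since the 1,3-thiazol-5-yl ring stays and only its methoxy group gives way to hydrogen, so that substituent can be read on its own for the first time, and it too stays within the scatter, though this is the widest gap among the three compounds. All three aromatic groups on this carbonyl carbon therefore give half-lives that cannot be told apart, and nothing measured here offers an explanation for that.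

Going by these compounds, all of these groups are aromatic rings, so it remains open whether a saturated ring such as piperidine, an amine or a plain methyl group on the same carbonyl carbon would keep the half-life in this range. Among these compounds, with only three compounds, each differing at this one place, the shared core's own contribution to the half-life also stays unknown.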